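Furan for thiophene on the nucleoside core: a note

This account rests on a few compounds, and the source may have more. Where it says the series, first, only, none or still open, it means among the compounds named here.

The series is read in a functional assay on K562 cells (Homo sapiens), read by MTT assay, with a stated time of 72 h; a lower number here means a stronger inhibitor, a higher number a weaker inhibitor. Compound 1 `Nc1nc(N)c2c(-c3ccsc3)cn([C@@H]3O[C@H](CO)[C@@H](O)[C@H]3O)c2n1` gives only a limit in this assay, > 20000 nM. Compound 2 `COc1nc(N)nc2c1c(-c1ccsc1)cn2[C@@H]1O[C@H](CO)[C@@H](O)[C@H]1O` likewise returns only a limit, > 20000 nM. Compound 3 `COc1ncnc2c1c(-c1ccccc1)cn2[C@@H]1O[C@H](CO)[C@@H](O)[C@H]1O` also gives only a limit, > 20000 nM. Going by the values given here, the single measured step made by one change, a step that the two limits leave unreadable from compound 1 to compound 2, cannot be read, since both of its ends sit at the same limit, (the limit of > 20000 nM in this assay, at which 3 of the 3 values shown sit). Compound 1 thus stands at the limit of this assay, with no number that would place it against the other two, which rest at the same limit.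

Compound 4 `Nc1nc(N)c2c(-c3ccoc3)cn([C@@H]3O[C@H](CO)[C@@H](O)[C@H]3O)c2n1` has not yet been measured. It differs from compound 1 by furan-3-yl in place of thiophen-3-yl on an aromatic carbon. Among the compounds with values here, no measured step touches the group at this place, and the one step that does exist between compound 1 and compound 2 is unreadable, so no size can be borrowed from it. Within the data shown here, with every value so far at the limit, the expectation for compound 4 rests on compound 1 alone. A step that the limit leaves unreadable from compound 1 to compound 4 is expected, none beyond the scatter. Compound 4 is therefore estimated at 30000 nM, within a range of 10000 nM to 100000 nM, and most probably reported again only as a limit in this assay.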

Compound 4, half-maximal inhibitory concentration: > 20000 nM
Compound 4 ended at the assay's limit; the forecaster's own chance of this, stated with the estimate: 85%; the middle value does not contradict the limit.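

Going by these compounds alone, compound 1 and compound 4 both sit at the same limit in this assay, so no step between them can be read: the limit of > 20000 nM in this assay, at which 4 of the 4 values shown sit.

The compounds shown leave open how furan-3-yl and thiophen-3-yl compare in this assay, and whether any change on the shared core gives a number rather than a limit.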